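Bridged bicyclic amine replacing isopropyl(methyl)amino on compound 1

The source may report more compounds than this note shows. Statements on the series, on what has been measured and on what is new or still open speak of the compounds shown alone.

Compound 1 `CC(C)N(C)c1ccc2cc(NC(=O)CCc3ccc(C(F)(F)F)cc3)ccc2n1` is the stronger of the two compounds measured in an assay on isolated protein for displacement of a labelled ligand from melanin-concentrating hormone receptor 1 (Homo sapiens); a higher number here means a weaker inhibitor, a lower number a stronger inhibitor: compound 1 gives 2 nM, while compound 2 `CCN(CC)c1ccc2cc(NC(=O)CCc3ccc(C(F)(F)F)cc3)ccc2n1` gives 88 nM, and the change from diethylamino in place of isopropyl(methyl)amino on an aromatic carbon produced a 44-fold higher number from compound 1 to compound 2 (1.64 log units; beyond the scatter). Compound 3 `O=C(CCc1ccc(C(F)(F)F)cc1)Nc1ccc2nc(N3CC4CCC3C4)ccc2c1`, not yet measured, differs from compound 1 as follows: a group of 7 heavy atoms (6 carbon, 1 nitrogen; one five-membered non-aromatic ring of carbon only, one five-membered non-aromatic ring with 1 hetero atom) in place of a group of 5 heavy atoms (4 carbon, 1 nitrogen; no ring), on an aromatic carbon. Among the measured compounds shown here, the only measured step that bears on this is the one from compound 1 to compound 2, which shows that even a small change at this amino group moved the number a great deal. The group entering in compound 3 is a larger departure, so a weaker number than for compound 1 is expected, though with wide uncertainty; compound 3 is estimated at 20 nM, with a range from 3 nM to 200 nM, corresponding to an expected step of a 10-fold higher number from compound 1 to compound 3 (1.00 log units; beyond the scatter).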

Compound 3, half-maximal inhibitory concentration: 1 nM
The estimate for compound 3 lay 20-fold (1.30 log units) above the measured number; the whole stated range lies above it.
By their numbers in this assay, from the lowest: compounds 3 and 1 (each within the scatter of the next); then compound 2.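

In this assay, the bridged bicyclic amine on the aromatic carbon next to the ring nitrogen gives a 2.0-fold lower number from compound 1 to compound 3 (0.30 log units; within the scatter), so this position accepts a group with two rings and more heavy atoms without a step beyond the scatter. The same group gives an 88-fold lower number from compound 2 to compound 3 (1.94 log units; beyond the scatter), which shows that the number here does not simply follow the heavy-atom count: diethylamino and isopropyl(methyl)amino have equal counts yet are far apart, while the larger bicyclic group stays level with isopropyl(methyl)amino. Nothing available explains these differences.

The compounds shown leave open whether the bridge is needed, or whether a simple pyrrolidine or piperidine ring at this position would give a similar number. They also leave open how dimethylamino or an isopropyl(ethyl)amino group would compare.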